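Swapping Bromo for Chloro on a Sulfonamide Scaffold

The source may report more compounds than this note shows. Statements on the series, on what has been measured and on what is new or still open speak of the compounds shown alone.

Of the compounds shown here, three have been measured in an ADME assay on MCF-10A cells (Homo sapiens) for antiproliferative activity, read by MTT assay (a higher number here means a weaker inhibitor, a lower number a stronger inhibitor), and a fourth awaits its number. Compound 1, with structure `C/C(=N/NC(=O)c1ccc(S(N)(=O)=O)cc1)c1ccc(Br)cc1`, gives 37600 nM in this assay. Compound 2, `C/C(=N/NC(=O)c1ccc(S(N)(=O)=O)cc1)c1ccc(Cl)cc1`, differs from compound 1 in one place: chloro in place of bromo on an aromatic carbon. In this assay compound 2 gives 62700 nM. That change moved the number by a 1.7-fold higher number from compound 1 to compound 2 (0.22 log units; within the scatter), a step within the usual scatter of repeated measurements.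

Compound 3, `NS(=O)(=O)c1ccc(N/C=C(\C(=O)c2ccc(Br)cc2)S(=O)(=O)c2ccccc2)cc1`, is built on a different core; the difference between the two cores is not broken down here. In this assay compound 3 gives 20400 nM, the lowest of the three numbers, though its gap to compound 1 lies within the scatter and only its gap to compound 2 lies beyond it.

Compound 4, `NS(=O)(=O)c1ccc(N/C=C(\C(=O)c2ccc(Cl)cc2)S(=O)(=O)c2ccccc2)cc1`, has not yet been measured. It relates to compound 3 exactly as compound 2 relates to compound 1: chloro in place of bromo on an aromatic carbon. The place is the same, word for word, on both cores, so this is the same change made a second time.

Because the earlier instance produced only a 1.7-fold higher number from compound 1 to compound 2 (0.22 log units; within the scatter), a small step is expected here as well. The expected step from compound 3 to compound 4 is a 1.5-fold higher number from compound 3 to compound 4 (0.17 log units; within the scatter), and the number estimated for compound 4 is 30000 nM, with a range from 12000 nM to 75000 nM that allows for the scatter of this assay.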

Compound 4, half-maximal inhibitory concentration: 28000 nM
Estimate against measurement, compound 4: 1.1-fold (0.03 log units) above; measured number inside the range.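

In this assay, putting chloro in place of bromo on the core of compound 3 gives a 1.4-fold higher number from compound 3 to compound 4 (0.14 log units; within the scatter), so this step is small, as it was on the first core. Set side by side, the two steps show no difference that can be told apart from ordinary repeat variation: the same change on two cores in this assay, a 1.7-fold higher number (0.22 log units; within the scatter) from compound 1 to compound 2 and a 1.4-fold higher number (0.14 log units; within the scatter) from compound 3 to compound 4, 1.2-fold (0.08 log units) apart, within the scatter of two such steps. This shows that, on these two cores, the swap behaved alike and changed little, so the earlier step was a fair guide to the later one; it does not show that bromo and chloro truly differ in this assay, since each step lies within the scatter, and two cores cannot speak for the whole series.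

The compounds shown carry only bromo or chloro at this place, on an aromatic carbon para to a large group, so it remains open whether a more different group there, such as an amine, a methoxy group or a carboxylic acid, would move the number beyond the scatter and whether such a step would carry from one core to the other as this one did.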